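The compounds below may be only part of what the source reports. "The series", "measured", "known", "first", "only" and "open" are said of these compounds alone.

Measured in a functional assay on NCI-H460 cells (Homo sapiens) for inhibition, with a stated time of 72 h; a lower number here means a stronger inhibitor, a higher number a weaker inhibitor:
- compound 1 `COc1cc(C(=O)c2cccc3[nH]ccc23)cc(OC)c1OC`: 53.8 nM
- compound 2 `COc1cc(C(=O)c2cccc3cc[nH]c23)cc(OC)c1OC`: 295 nM
- compound 3 `CCCn1ccc2cc(C(=O)c3cc(OC)c(OC)c(OC)c3)ccc21`: 2000 nM

Compound 3 has the highest number of the three, which makes it the weakest inhibitor here. Its gaps to the other two both lie beyond the usual scatter of repeated measurements.

Compound 4 `COc1cc(C(=O)c2ccc3c(ccn3CC(=O)O)c2)cc(OC)c1OC` keeps the core of compound 3 and alters only the chain, turning propyl into carboxymethyl. This places carboxy in place of ethyl on a saturated chain carbon bound to an aromatic nitrogen.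

Among the compounds with values here, no measured pair here shows this kind of change on its own, so any forecast is loose. Within the data shown here, compound 3 is the only measured compound with a propyl group, and at 2000 nM it offers no sign of strong inhibition to build on. In this assay, a moderate move towards weaker inhibition is expected, estimated as a 3.0-fold higher number from compound 3 to compound 4 (0.48 log units; beyond the scatter). The assay may also report only a limit. For compound 4 the estimated value is 6000 nM, with an expected range of 2000 nM to 20000 nM.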

Compound 4, half-maximal inhibitory concentration: 530 nM
For compound 4 the middle estimate is 11-fold (1.05 log units) above the measured one, and the stated range ends above it.
By their numbers in this assay, from the lowest: compound 1; then compounds 2 and 4 (each within the scatter of the next); then compound 3.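

In this assay, within the data shown here, the first measured change to the chain on the aromatic nitrogen gives a 3.8-fold lower number from compound 3 to compound 4 (0.58 log units; beyond the scatter) and so points towards stronger inhibition when carboxy takes the place of ethyl. The step is modest but lies beyond the scatter, which shows that this position can carry a carboxy group, with its hydrogen-bond donor and acceptor, without any loss of inhibition. Nothing measured here explains the gain, so its cause stays unknown.

A single step cannot separate what the carboxy group adds from what is lost with the ethyl end of the propyl chain. The compounds shown leave open how a methyl ester, an amide, an amine or a longer chain ending in a carboxylic acid would fare on the same nitrogen.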